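Fluorine on the benzamide ring in two related cores

This account rests on a few compounds, and the source may have more. Where it says the series, first, only, none or still open, it means among the compounds named here.

Measured so far in a functional assay on MCF7 cells (Homo sapiens) for cytotoxicity, read by MTT assay, with a stated time of 72 h; a higher number here means a weaker inhibitor, a lower number a stronger inhibitor:
Compound 1, `Cc1cn(C/C=C\CNC(=O)c2ccccc2)c(=O)[nH]c1=O`, in this assay gives > 100000 nM, which is a limit of the assay and not a number.
Compound 3, `Cc1cn(C/C=C\CNC(=O)c2ccc(F)cc2)c(=O)[nH]c1=O`, in this assay gives 24100 nM.
Compound 2, `Nc1ccn(C/C=C\CNC(=O)c2ccccc2)c(=O)n1`, in this assay gives 31400 nM.

Compound 1 and compound 2 share the butenyl benzamide arm but carry different cores; the difference between the two cores is not broken down here. Within the core of compound 1, the single change fluoro in place of hydrogen on an aromatic carbon gives an at least 4.1-fold lower number from compound 1 to compound 3 (0.61 log units; beyond the scatter). The size of that step is open at the top because of the limit of > 100000 nM in this assay, at which 1 of the 3 values shown sits, so only its lower bound is known. Compound 2 and compound 3 sit within the usual scatter of each other, so no order between them is read.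

Compound 4, `Nc1ccn(C/C=C\CNC(=O)c2ccc(F)cc2)c(=O)n1`, is not yet measured. Among the measured compounds shown here, it differs from compound 2 by fluoro in place of hydrogen on an aromatic carbon, the same change, at the same place, as the one from compound 1 to compound 3. On that single precedent, and on the value of compound 2 in this assay, a step of a 2.9-fold lower number from compound 2 to compound 4 (0.46 log units; beyond the scatter) is expected from compound 2 to compound 4. For the measured compounds named here, compound 4 is therefore estimated at 11000 nM in this assay, with an expected range from 3500 nM to 40000 nM; the range is wide since the only measured instance of this change starts from a limit.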

Compound 4, half-maximal inhibitory concentration: > 100000 nM
Compound 4: only a limit was reported (the forecaster's own chance of this, stated with the estimate: 5%); middle value at least 9.0-fold (0.95 log units) away from the limit.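

In this assay compound 4 gives > 100000 nM, which is a limit of the assay and not a number. The change from phenyl to 4-fluorophenyl gives an at least 3.1-fold higher number from compound 2 to compound 4 (0.50 log units; beyond the scatter), so the direction seen on the core of compound 1 does not carry over to the core of compound 2: the same change on two cores in this assay, an at least 4.1-fold lower number (0.61 log units; beyond the scatter) from compound 1 to compound 3 and an at least 3.1-fold higher number (0.50 log units; beyond the scatter) from compound 2 to compound 4, at least 13-fold (1.12 log units) apart, beyond the scatter of two such steps The size of neither step is known, and with one pair on each core the result gives no rule for other cores and no reason for the reversal: the limit of > 100000 nM in this assay, at which 2 of the 4 values shown sit.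

Still open, as far as these compounds go, is whether the split between the two cores is specific to fluoro, or also appears with chloro, methoxy or an amine on the same aromatic carbon of the benzamide ring. Also open, from the compounds shown here alone, is whether it persists with a longer chain in place of the butenyl arm.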